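From chloro to methyl on the shared core

The source may hold more compounds than are shown below. What is called first, only, known or untested is meant among the compounds shown, and "the series" means these compounds.

In an ADME assay on microsomes from liver (Homo sapiens) for metabolic stability (on this read-out lower numbers stand for a shorter-lived compound and higher numbers for a longer-lived compound), compound 3 (`CC#C[C@@H](Cc1nnn[nH]1)c1ccc(OCc2ccc3sc(Cl)c(-c4ccccc4C)c3c2)cc1`) gives 0.175 h as the second highest of three measured numbers. Compound 1 (`CC#C[C@@H](Cc1nnn[nH]1)c1ccc(OCc2ccc3sc(C#N)c(-c4ccccc4C)c3c2)cc1`) reads 0.0333 h and sits lowest, while compound 2 (`CC#C[C@@H](Cc1nnn[nH]1)c1ccc(OCc2ccc3scc(-c4ccc(OCCC(C)(C)O)cc4C)c3c2)cc1`) reads 0.95 h and sits highest. Compound 4 (`CC#C[C@@H](Cc1nnn[nH]1)c1ccc(OCc2ccc3sc(C)c(-c4ccccc4C)c3c2)cc1`) has methyl in place of chloro on an aromatic carbon and is otherwise the same as compound 3. Among the compounds with values here, the one measured step at this carbon, chloro in place of cyano, gave a 5.3-fold higher number from compound 1 to compound 3 (0.72 log units; beyond the scatter) and lies beyond the scatter. Within the data shown here, no measured compound carries methyl there, so the expected step is small, estimated as a 1.3-fold lower number from compound 3 to compound 4 (0.13 log units; within the scatter) and not clearly beyond the scatter. In this assay compound 4 is estimated at 0.13 h with an expected range of 0.05 h to 0.35 h as its bounds.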

Compound 4, half-life: 0.0667 h
The estimate for compound 4 lay 1.9-fold (0.29 log units) above the measured number, within the range that was stated.
By their numbers in this assay, from the lowest: compounds 1 and 4 (each within the scatter of the next); then compound 3; then compound 2.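

In this assay, putting methyl in place of chloro at this carbon gives a 2.6-fold lower number from compound 3 to compound 4 (0.42 log units; beyond the scatter) and so reverses much of the earlier gain from chloro. Methyl does not separate from cyano, with a 2.0-fold higher number from compound 1 to compound 4 (0.30 log units; within the scatter) among the compounds shown, which leaves chloro as the one group of the three that stands apart here. No available evidence bears on what lies behind this difference. The compounds shown leave open how fluoro, bromo, methoxy or an amine would read at this carbon, and whether the chloro result would hold alongside the longer chain of compound 2.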